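Swapping the dichlorophenyl for a trifluoromethylphenyl

The compounds below may be only part of what the source reports. "The series", "measured", "known", "first", "only" and "open" are said of these compounds alone.

Of the compounds shown here, three sharing one core have been tested in a functional assay on L1210 cells (Mus musculus) for antiproliferative activity; on this read-out lower numbers stand for stronger inhibition and higher numbers for weaker inhibition. Compound 1 `COc1cc(C(=O)c2sc(-c3ccc(C)cc3)cc2N)cc(OC)c1OC` gives 18 nM, compound 2 `COc1cc(C(=O)c2sc(-c3cccs3)cc2N)cc(OC)c1OC` gives 9.8 nM, and compound 3 `COc1cc(C(=O)c2sc(-c3ccc(Cl)c(Cl)c3)cc2N)cc(OC)c1OC` gives 260 nM. Compound 3 therefore has the highest number of the three, the weakest inhibition seen so far: the step of a 14-fold higher number from compound 1 to compound 3 (1.16 log units; beyond the scatter) and the step of a 27-fold higher number from compound 2 to compound 3 (1.42 log units; beyond the scatter) both lie well beyond the scatter, whereas the step of a 1.8-fold lower number from compound 1 to compound 2 (0.26 log units; within the scatter) does not.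

Compound 4 `COc1cc(C(=O)c2sc(-c3ccc(C(F)(F)F)cc3)cc2N)cc(OC)c1OC` differs from compound 3 in one place: 4-(trifluoromethyl)phenyl in place of 3,4-dichlorophenyl on an aromatic carbon. Going by the values given here, the only measured steps that bear on this change are the two that leave the 3,4-dichlorophenyl of compound 3, and both gave far lower numbers. Among the compounds with values here, the group that enters is, like the 4-methylphenyl of compound 1, a phenyl with a single substituent at its 4-position, but no measured step tells how a trifluoromethyl there behaves. The expectation is therefore a number in this assay between those of compound 3 and compound 1, with the step of a 2.2-fold lower number from compound 3 to compound 4 (0.34 log units; beyond the scatter) expected to be modest and toward stronger inhibition. Compound 4 is thus estimated at 120 nM, within a range from 30 nM to 500 nM.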

Compound 4, half-maximal inhibitory concentration: 370 nM
Estimate against measurement, compound 4: 3.1-fold (0.49 log units) below; low and high end bracket the measured number.
By their numbers in this assay, from the lowest: compounds 2 and 1 (each within the scatter of the next); then compounds 3 and 4 (each within the scatter of the next).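

In this assay, the 4-(trifluoromethyl)phenyl and the 3,4-dichlorophenyl at this place on the shared core cannot be told apart (a 1.4-fold higher number from compound 3 to compound 4 (0.15 log units; within the scatter)), so this swap does not bring back the low numbers of the two earlier compounds. The larger lesson comes from the comparison with compound 1: the 4-methylphenyl and the 4-(trifluoromethyl)phenyl differ only in trifluoromethyl in place of methyl, yet that small change alone gives a large step (a 21-fold higher number from compound 1 to compound 4 (1.31 log units; beyond the scatter)), and the gap to the thiophen-2-yl compound is just as clear (a 38-fold higher number from compound 2 to compound 4 (1.58 log units; beyond the scatter)). A phenyl ring with one group in this arrangement is therefore no guarantee of a low number, since the identity of that group matters, although nothing available here explains why.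

Still open, as far as these compounds go, is whether a 4-chlorophenyl, a 4-methoxyphenyl or a 4-(dimethylamino)phenyl would fall with compound 1 or with compound 3 and compound 4. Also open, from the compounds shown here alone, is whether another five-membered ring, such as a furan-2-yl, would give a number as low as that of the thiophen-2-yl in compound 2.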